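Extending the Linker of Compound 3 by One Carbon

This account rests on a few compounds, and the source may have more. Where it says the series, first, only, none or still open, it means among the compounds named here.

Compound 1 `COc1ccccc1-c1cc(=O)c2c(O)cc(OCCCCN3CCN(C)CC3)c(OC)c2o1` gives 5430 nM in a functional assay on MCF7 cells (Homo sapiens) for cytotoxicity, read by MTT assay, with a stated time of 72 h; on this read-out higher numbers stand for weaker inhibition and lower numbers for stronger inhibition.
Compound 2 `CN(C)CCCOc1c(OCc2ccccc2)cc(O)c2c(=O)cc(-c3ccccc3)oc12` gives 3210 nM.
Compound 3 `CN1CCN(CCCOc2c(OCc3ccccc3)cc(O)c3c(=O)cc(-c4ccccc4)oc23)CC1` gives 1020 nM.

Compound 3 holds the lowest number of the three; its gaps to compound 2 and to compound 1 both lie beyond the scatter. Compound 4 `CN1CCN(CCCCOc2c(OCc3ccccc3)cc(O)c3c(=O)cc(-c4ccccc4)oc23)CC1` differs from compound 3 by (4-methylpiperazin-1-yl)methyl in place of 4-methylpiperazin-1-yl on a saturated chain carbon, three bonds along the chain from an oxygen on an aromatic ring, that is, the chain becomes 4-(4-methylpiperazin-1-yl)butyl. Among the compounds with values here, the only measured step, a 3.1-fold lower number from compound 2 to compound 3 (0.50 log units; beyond the scatter), concerns the amine, not the chain, so it does not bear directly on this change. Compound 1 also carries a butyl chain but differs elsewhere too, so its value alone settles nothing. Compound 4 is therefore expected to stay near compound 3, with a 1.2-fold higher number from compound 3 to compound 4 (0.07 log units; within the scatter) not beyond the scatter. The estimate for compound 4 is 1200 nM, within 500 nM to 3000 nM.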

Compound 4, half-maximal inhibitory concentration: 2930 nM
Compound 4: the middle estimate sits 2.4-fold (0.39 log units) below what was measured; the range from low to high includes it.
By their numbers in this assay, from the lowest: compound 3; then compounds 4, 2 and 1 (each within the scatter of the next).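

At this position on the chain, length matters: the 4-(4-methylpiperazin-1-yl)butyl chain of compound 4 gives a 2.9-fold higher number from compound 3 to compound 4 (0.46 log units; beyond the scatter) in this assay on the addition of one carbon. The added carbon also leaves no separation from the dimethylamino compound, with a 1.1-fold lower number from compound 2 to compound 4 (0.04 log units; within the scatter) on the printed scale. Nothing available explains this loss. Still open, from the compounds shown here alone, is whether a shorter 2-(4-methylpiperazin-1-yl)ethyl chain would give a lower number than compound 3 does. Also open, going by these compounds, is how a morpholine in place of 4-methylpiperazin-1-yl would read on the propyl chain.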